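This account rests on a few compounds, and the source may have more. Where it says the series, first, only, none or still open, it means among the compounds named here.

Measured compounds:
Compound 1 `CC(C)=CCOc1cc(=O)n(CCCO)c2c1CC(CC=C(C)C)C(C)(C)C2` gives 7.5% in a functional assay on PANC-1 cells (Homo sapiens) for inhibition, read by MTT assay, with a stated time of 24 h, tested at 10 uM; a lower number here means less inhibition, a higher number more inhibition at the concentration tested (going by the name of the read-out).
Compound 2 `CCOc1cc(=O)n(CCCO)c2c1CC(C/C=C(\C)CCC=C(C)C)C(C)(C)C2` gives 0.8% in this assay.

Compound 2 holds the lowest of the two numbers, and its nearest neighbour is compound 1, whose value lies within the usual scatter of such measurements, so no order can be read between the two. Compound 3 `CC(C)=CCC/C(C)=C/CC1Cc2c(OCC=C(C)C)cc(=O)n(CCCO)c2CC1(C)C` has not yet been measured in this assay. It differs from compound 2 in one place: 2-methylprop-1-en-1-yl in place of methyl on a saturated chain carbon bound to an oxygen on an aromatic ring. Among the compounds with values here, no measured pair shares this change, so its size is not known from the data. Compound 1 already carries the (3-methylbut-2-en-1-yl)oxy group on the shared core and gives a low number, and compound 2 gives a low number as well. The step from compound 2 to compound 3 is therefore expected to be a number 4.2 percentage points higher from compound 2 to compound 3 (within the scatter), which is no change beyond the scatter. For compound 3 the estimate in this assay is 5%, within a range from 0% to 15%.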

Compound 3, a percentage reported as inhibition, at one concentration (the size of the read-out at that concentration, not a potency): 15.9%
Estimate against measurement, compound 3: 10.9 percentage points below, outside the stated range (above it).
By their numbers in this assay, from the lowest: compounds 2, 1 and 3 (each within the scatter of the next, the first and the last beyond it).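

With the rest of the structure unchanged, placing 2-methylprop-1-en-1-yl in place of methyl on a saturated chain carbon bound to an oxygen on an aromatic ring, which turns ethoxy into (3-methylbut-2-en-1-yl)oxy, gives a number 15.1 percentage points higher from compound 2 to compound 3 (beyond the scatter) in this assay; this modest step shows that the number responds to a change at this position. The second change, 3-methylbut-2-en-1-yl in place of hydrogen on a saturated chain carbon bound to a double-bonded chain carbon, gives a number 8.4 percentage points higher from compound 1 to compound 3 (within the scatter), so its effect cannot be told from the scatter. Nothing available accounts for the step at the oxygen-bound chain.

The compounds shown leave open how a benzyl group, a longer chain or a terminal amine would fare on that oxygen. They also leave open whether the step holds at other concentrations, since each number comes from a single one.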